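The compounds below may be only part of what the source reports. "The series", "measured", "known", "first", "only" and "open" are said of these compounds alone.

Compound 1 `C#CCOc1ccc(/C=C/C(=O)c2cccc(C)c2)cc1OC` gives, in a functional assay on CCRF-CEM cells (Homo sapiens) for cytotoxicity, with a stated time of 72 h (a lower number here means a stronger inhibitor, a higher number a weaker inhibitor), 8820 nM.
Compound 2 `C#CCOc1ccc(/C=C/C(=O)c2ccc(C)cc2)cc1OC` gives in this assay only a limit, > 50000 nM.

Compound 2 thus stands at a limit rather than a number; the step of an at least 5.6-fold higher number from compound 1 to compound 2 (0.75 log units; beyond the scatter) was beyond the scatter and ended at the limit of > 50000 nM in this assay, at which 1 of the 2 values shown sits. Compound 3 `C#CCOc1ccc(/C=C/C(=O)c2cccc(Br)c2)cc1OC` is reached by 3-bromophenyl in place of 4-methylphenyl on a carbonyl carbon, which undoes the exchange of 3-methylphenyl for 4-methylphenyl and additionally puts bromine where methyl was, a change without a measured step here. Because an at least 5.6-fold higher number from compound 1 to compound 2 (0.75 log units; beyond the scatter) ran toward weaker inhibition, a step back toward stronger inhibition is expected. Compound 3 is therefore estimated at 10000 nM (range 3000 nM to 50000 nM), an expected step of an at least 5.0-fold lower number from compound 2 to compound 3 (0.69 log units; beyond the scatter).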

Compound 3, half-maximal inhibitory concentration: 15200 nM
Compound 3: middle estimate off by 1.5-fold (0.18 log units), on the low side; measured number inside the range.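

Bromo in place of methyl on an aromatic carbon gives a 1.7-fold higher number from compound 1 to compound 3 (0.24 log units; within the scatter), so in this assay the 3-methylphenyl and 3-bromophenyl groups cannot be told apart. The change from 4-methylphenyl to 3-bromophenyl on the carbonyl carbon gives an at least 3.2-fold lower number from compound 2 to compound 3 (0.51 log units; beyond the scatter), which places both compounds carrying a 3-substituted phenyl clear of compound 2. Compound 2 gives a limit and not a number: the limit of > 50000 nM in this assay, at which 1 of the 3 values shown sits.

Open, as far as these compounds go, is whether 4-bromophenyl would match 4-methylphenyl or 3-bromophenyl. Also open, from the compounds shown here alone, is how a phenyl bearing an amine or a carboxylic acid would fare on this carbonyl carbon.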